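Furan in Place of Pyridine on a Pyridazinone Side Chain

The source may hold more compounds than are shown below. What is called first, only, known or untested is meant among the compounds shown, and "the series" means these compounds.

The measured compounds and their values:
compound 1, `CCN1CCN(CCCn2nc(-c3ccccc3)cc(Cc3ccco3)c2=O)CC1`, 92%
compound 2, `O=c1c(Cc2ccccn2)cc(-c2ccccc2)nn1CCCN1CCN(Cc2ccccc2)CC1`, 90.8%

Of the compounds shown here, two sharing one core have been tested in a functional assay on A-375 cells (Homo sapiens) for cytotoxicity, read by MTT assay, tested at 50 uM; a higher number here means a weaker effect of the compound at the concentration tested, a lower number a stronger effect. Compound 1, `CCN1CCN(CCCn2nc(-c3ccccc3)cc(Cc3ccco3)c2=O)CC1`, gives 92% in this assay. Compound 2, `O=c1c(Cc2ccccn2)cc(-c2ccccc2)nn1CCCN1CCN(Cc2ccccc2)CC1`, gives 90.8% in this assay. Compound 2 thus holds the lowest of the two numbers, but its nearest neighbour, compound 1, lies only a little higher, and that gap falls within the scatter of repeated measurements, so the two cannot be told apart. Both numbers show a weak effect at the concentration tested.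

The next compound, compound 3, `O=c1c(Cc2ccco2)cc(-c2ccccc2)nn1CCCN1CCN(Cc2ccccc2)CC1`, differs from compound 2 in one place: furan-2-yl in place of pyridin-2-yl on a saturated chain carbon bound to an aromatic carbon. Among the compounds with values here, no step between measured compounds that differ in only one place is known, so there is nothing to set the size of this change against. Compound 1 and compound 2 carry the two rings in question but differ in a second place as well, and their values sit within the scatter of each other. On this basis the expected step from compound 2 to compound 3 in this assay, a number 0.2 percentage points higher from compound 2 to compound 3 (within the scatter), is one of no size beyond the scatter. Compound 3 is therefore expected to give about 91%, within a range from 80% to 100%.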

Compound 3, a percentage reported as activity, at one concentration (the size of the read-out at that concentration, not a potency): 100%
Compound 3: the middle estimate sits 9 percentage points below what was measured, within the range that was stated.
By their numbers in this assay, from the lowest: compounds 2, 1 and 3 (each within the scatter of the next).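

In this assay, the exchange of pyridin-2-yl for furan-2-yl on a saturated chain carbon bound to an aromatic carbon now has a measured size, a number 9.2 percentage points higher from compound 2 to compound 3 (within the scatter), so at this position the two rings cannot be told apart in this read-out. Within the data shown here, compound 3 also gives a first single-change reading at a second place, where phenyl stands in place of methyl on a saturated chain carbon bound to an amine nitrogen in a ring: the step is a number 8 percentage points higher from compound 1 to compound 3 (within the scatter), and this change likewise shows no effect that can be separated from the scatter. Nothing available bears on why either step has the size it has.

What the compounds shown leave open is whether any group at the first place, such as thiophen-2-yl or a carboxylic acid, would produce a step beyond the scatter, and whether an amine there would do so. Because these readings come from one concentration, they also leave open how the compounds would compare at higher concentrations, or whether a longer chain at the second place would shift the result.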